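The source may hold more compounds than are shown below. What is called first, only, known or untested is meant among the compounds shown, and "the series" means these compounds.

In a functional assay on SiHa cells (Homo sapiens) for cytotoxicity, with a stated time of 4 h (on this read-out higher numbers stand for weaker inhibition and lower numbers for stronger inhibition), compound 1 `CC(C)c1ccc2c(c1)[n+]([O-])c(NCCN1CCCCC1)n[n+]2[O-]` gives 1100 nM. Compound 2 `CCCN(CCC)CCNc1n[n+]([O-])c2ccc(C(C)C)cc2[n+]1[O-]` carries dipropylamino in place of piperidin-1-yl on a saturated chain carbon, two bonds along the chain from a nitrogen on an aromatic ring and in this assay compound 2 gives 900 nM, a step of a 1.2-fold lower number from compound 1 to compound 2 (0.09 log units; within the scatter). Compound 3 `CC(C)(C)c1ccc2c(c1)[n+]([O-])c(NCCN1CCCCC1)n[n+]2[O-]` differs from compound 1 in its core by methyl in place of hydrogen on a saturated chain carbon bound to an aromatic carbon and two saturated chain carbons; in this assay compound 3 gives 600 nM, a step of a 1.8-fold lower number from compound 1 to compound 3 (0.26 log units; within the scatter). Compound 4 `CCCN(CCC)CCNc1n[n+]([O-])c2ccc(C(C)(C)C)cc2[n+]1[O-]` has not yet been measured. It differs from compound 3 by dipropylamino in place of piperidin-1-yl on a saturated chain carbon, two bonds along the chain from a nitrogen on an aromatic ring, the same change seen between compound 1 and compound 2, at the same place. The step expected here is a 1.2-fold lower number from compound 3 to compound 4 (0.08 log units; within the scatter), set beside the earlier 1.2-fold lower number from compound 1 to compound 2 (0.09 log units; within the scatter), because that earlier step a 1.2-fold lower number from compound 1 to compound 2 (0.09 log units; within the scatter) was small and within the scatter. For compound 4 the estimate in this assay is 500 nM, within a range from 250 nM to 1000 nM.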

Compound 4, half-maximal inhibitory concentration: 3800 nM
For compound 4 the middle estimate is 7.6-fold (0.88 log units) below the measured one, and the stated range ends below it.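

In this assay, dipropylamino in place of piperidin-1-yl did not carry over from one core to the other, giving a 6.3-fold higher number from compound 3 to compound 4 (0.80 log units; beyond the scatter), a different outcome from the earlier step: the same change on two cores in this assay, a 1.2-fold lower number (0.09 log units; within the scatter) from compound 1 to compound 2 and a 6.3-fold higher number (0.80 log units; beyond the scatter) from compound 3 to compound 4, 7.7-fold (0.89 log units) apart, beyond the scatter of two such steps. Read the other way round, methyl in place of hydrogen on the saturated chain carbon gives a 4.2-fold higher number from compound 2 to compound 4 (0.63 log units; beyond the scatter), which likewise departs from its earlier counterpart: the same change on two cores in this assay, a 1.8-fold lower number (0.26 log units; within the scatter) from compound 1 to compound 3 and a 4.2-fold higher number (0.63 log units; beyond the scatter) from compound 2 to compound 4, 7.7-fold (0.89 log units) apart, beyond the scatter of two such steps. The two changes therefore do not add up independently here, but both comparisons rest on the same four compounds, so they form a single observation and do not show why the steps differ.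

On these data alone, it remains open whether diethylamino or morpholin-4-yl at the same place would behave like dipropylamino. As far as these compounds go, it is also open whether a similar gap would appear with a longer chain between the two nitrogens.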